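Series notes: the step from compound 3 to compound 4

The source may report more compounds than this note shows. Statements on the series, on what has been measured and on what is new or still open speak of the compounds shown alone.

Values in a functional assay on HL-60 cells (Homo sapiens) for cytotoxicity, read by MTT assay, with a stated time of 48 h; on this read-out higher numbers stand for weaker inhibition and lower numbers for stronger inhibition:
compound 1 `Fc1ccc2nc(-c3ccccc3)nc(Nc3ccccc3)c2c1`: > 50000 nM, a limit.
compound 2 `COc1ccc(Nc2nc(-c3cccc(F)c3)nc3ccc(F)cc23)cc1`: 38600 nM.
compound 3 `Fc1cccc(-c2nc(Nc3ccccc3Cl)c3cc(F)ccc3n2)c1`: > 50000 nM, a limit.

Compound 3 sits at the limit of > 50000 nM in this assay, at which 2 of the 3 values shown sit. Within the data shown here, the one measured step that reaches it, an at least 1.2-fold higher number from compound 2 to compound 3 (0.11 log units; that floor lies within the scatter), changes the aryl on the nitrogen and ends at that limit, so it gives a floor only. Compound 4 `Cc1ccccc1Nc1nc(-c2cccc(F)c2)nc2ccc(F)cc12` differs from compound 3 by methyl in place of chloro on an aromatic carbon. Among the measured compounds shown here, no measured step exchanges methyl for chloro, and no step in the set produces a change beyond the scatter, so no step beyond the scatter is expected in this assay either way. Compound 4 is therefore expected at 70000 nM, most likely reported as a limit again, within 30000 nM to 200000 nM, meaning an expected step that the limit leaves unreadable from compound 3 to compound 4.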

Compound 4, half-maximal inhibitory concentration: > 50000 nM
Compound 4 was reported as a limit; the forecaster's own chance of this, stated with the estimate: 75%; the middle value is on the limit's open side.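

In this assay compound 4 gives > 50000 nM, a limit, so a 2-methylphenyl on the nitrogen ends where the 2-chlorophenyl does. Among these compounds, the only readable step is an at least 1.2-fold higher number from compound 2 to compound 4 (0.11 log units; that floor lies within the scatter), a floor and no more. The exchange of methyl for chloro on this aromatic carbon cannot be read, and the set stays pressed against one limit: the limit of > 50000 nM in this assay, at which 3 of the 4 values shown sit.

From the compounds shown here alone, whether an amine or a carboxylic acid on this aromatic carbon would give a value clear of the limit stays open. So does whether the 4-methoxyphenyl matters, with both floors inside the scatter.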